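Fluoro to Hydroxy on the Aryl Arm: Expected Shift

The source may report more compounds than this note shows. Statements on the series, on what has been measured and on what is new or still open speak of the compounds shown alone.

Going by the values given here, compound 1 `Fc1ccc(/C=N/NC(=S)Nc2nc3ccc(Cl)cc3s2)cc1` gives 30 mg/kg in a functional assay on the whole organism with Mus musculus as the target, in the maximal electroshock model, with a stated time of 0.5 h (on this read-out lower numbers stand for an effect already at smaller amounts and higher numbers for an effect only at larger amounts of compound), the lowest of the two numbers measured so far. Compound 2 `O=C(Cn1ccc2ccccc21)Nc1nc2ccc(Cl)cc2s1` gives 100 mg/kg in this assay, a gap to compound 1 that lies beyond the usual scatter. Compound 3 `Oc1ccc(/C=N/NC(=S)Nc2nc3ccc(Cl)cc3s2)cc1` remains to be measured; it differs from compound 1 in one place: hydroxy in place of fluoro on an aromatic carbon. Among the compounds with values here, no step between measured compounds covers a change of this kind, so a step of modest size, in either direction, or none beyond the scatter, is expected from compound 1 to compound 3 in this assay; the estimate is no change at the digits printed from compound 1 to compound 3 (within the scatter). Compound 3 is expected to give 30 mg/kg, in the range 10 mg/kg to 100 mg/kg.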

Compound 3, minimum effective dose: 100 mg/kg
Beside the measured number, compound 3's estimate is 3.3-fold (0.52 log units) below it; measured number inside the range.
By their numbers in this assay, from the lowest: compound 1; then compounds 2 and 3 (each within the scatter of the next).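

Replacing the 4-fluorophenyl with the 4-hydroxyphenyl gives a 3.3-fold higher number from compound 1 to compound 3 (0.52 log units; beyond the scatter) in this assay and so shows that the aromatic carbon para to a large group is not indifferent to the group it carries. Going by these compounds alone, this is the first step that isolates one change, and here the fluoro compound needs the smaller dose. Nothing measured on these compounds accounts for the shift.

Open, going by these compounds, is how a methoxy group, an amine or a carboxylic acid would read at this place. Also open, on these data alone, is whether the plain phenyl stands nearer compound 1 or compound 3.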